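This account rests on a few compounds, and the source may have more. Where it says the series, first, only, none or still open, it means among the compounds named here.

Working notes on the series. In a physicochemical assay on cells (Homo sapiens), with a stated time of 18 h, tested at 1 uM (a higher number here means a weaker effect of the compound at the concentration tested, a lower number a stronger effect), compound 1 `COc1cc(/C=N/NC(=O)OCc2ccccc2)cc(O)c1O` gives 17%. Compound 2 `COc1cc(/C=N/NC(=O)OCc2ccccc2)ccc1O` gives 75% in this assay, and compound 3 `COc1cc(/C=N/Nc2nc3ccccc3s2)ccc1O` gives 65%. The values of compound 2 and compound 3 lie within the scatter of each other, so no order between them is read. The difference between the cores of compound 2 and compound 3 is not broken down here. Compound 1 differs from compound 2 by hydroxy in place of hydrogen on an aromatic carbon; this change produced a number 58 percentage points lower from compound 2 to compound 1 (beyond the scatter). Compound 4 `COc1cc(/C=N/Nc2nc3ccccc3s2)cc(O)c1O` is not yet measured in this assay; it differs from compound 3 by hydroxy in place of hydrogen on an aromatic carbon, which is the same change with the same surroundings of the place, made on the core of compound 3 instead. Among the measured compounds shown here, because the earlier occurrence of this change gave a number 58 percentage points lower from compound 2 to compound 1 (beyond the scatter), a step of similar size is expected here, namely a number 50 percentage points lower from compound 3 to compound 4 (beyond the scatter), with some caution since the cores differ and only one prior step is known. Compound 4 is therefore estimated at 15% in this assay, with a likely range of 4% to 40%.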

Compound 4, a percentage reported as activity, at one concentration (the size of the read-out at that concentration, not a potency): 56%
Compound 4: middle estimate off by 41 percentage points, on the low side, and the stated range ends below it.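

In this assay, hydroxy in place of hydrogen on an aromatic carbon gave a number 58 percentage points lower from compound 2 to compound 1 (beyond the scatter) on one core but a number 9 percentage points lower from compound 3 to compound 4 (within the scatter) on the other, so a step beyond the scatter on the core of compound 2 did not carry over to the core of compound 3, although the surroundings of the place are the same. Among the compounds shown here, with a single pair on each core, this shows only that the earlier step could not be transferred between these two cores; it gives no rule for other cores and does not show that the hydroxy is without any effect on the core of compound 3, only that the step there lies within the scatter. No evidence is available on what separates the two cores in their response to this change.

Going by these compounds, it remains open how an amine or a carboxylic acid at the same place would read on either core. Also open, on these data alone, is whether the large step seen with the core of compound 2 recurs on any further core.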